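The compounds below may be only part of what the source reports. "The series", "measured", "known", "first", "only" and "open" are said of these compounds alone.

Working notes on the series. Compound 1 `CCCCC(O)c1cccc(NC(=O)NC(=O)CCl)c1` carries a 1-hydroxypentyl chain and an acylurea ending in chloro. In a functional assay on HT-29 cells (Homo sapiens) for antiproliferative activity, with a stated time of 48 h (a higher number here means a weaker inhibitor, a lower number a stronger inhibitor), compound 1 gives 10000 nM. Compound 2 `CCCCC(O)c1cccc(NC(=O)NC(=O)CC)c1` has methyl in place of chloro on a saturated chain carbon bound to a carbonyl carbon. In this assay compound 2 gives only a limit, > 100000 nM. Among the measured compounds shown here, the single measured step is an at least 10-fold higher number from compound 1 to compound 2 (1.00 log units; beyond the scatter). Compound 3 `CCCCCc1cccc(NC(=O)CCCCl)c1` pairs a plain pentyl chain with a chloro-terminated amide. In this assay compound 3 gives only a limit, > 100000 nM. Compound 3 thus stands at the limit of > 100000 nM in this assay, at which 2 of the 3 values shown sit, with no number of its own.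

Compound 4 `CCCCC(O)c1cccc(NC(=O)CCCCl)c1` differs from compound 3 by hydroxy in place of hydrogen on a saturated chain carbon bound to an aromatic carbon and a saturated chain carbon. For the measured compounds named here, no measured step concerns a hydroxy change; the step from chloro to methyl lies on the other side of the molecule, and compound 1 and compound 3 differ in both places at once, so no clean reading exists. With compound 3 at the limit, compound 4 is expected to stay close to it, and the estimated step of an at least 1.4-fold lower number from compound 3 to compound 4 (0.15 log units; that floor lies within the scatter) is expected to be small. For compound 4 the estimate in this assay is 70000 nM, within 15000 nM to 150000 nM.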

Compound 4, half-maximal inhibitory concentration: > 100000 nM
Compound 4 was reported as a limit (the forecaster's own chance of this, stated with the estimate: 60%); middle value at least 1.4-fold (0.15 log units) from the limit.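

Going from pentyl to 1-hydroxypentyl does not lift the chloro-terminated amide off the limit in this assay: compound 3 and compound 4 are both reported only as limits, and neither the step between them nor the step from compound 2 to compound 4 can be read. With the 1-hydroxypentyl chain held constant, 3-chloropropyl in place of ((chloromethyl)carbonyl)amino on a carbonyl carbon gives an at least 10-fold higher number from compound 1 to compound 4 (1.00 log units; beyond the scatter), so neither that chain nor a terminal chloro is enough on its own to give a value short of the limit in this set. Compound 1 alone remains off the limit shared by the rest: the limit of > 100000 nM in this assay, at which 3 of the 4 values shown sit.

Any effect of hydroxy in the amide pair stays unresolved. Also open, from the compounds shown here alone, is how an amine in place of chloro, or a longer chain in place of the 1-hydroxypentyl chain, would read on the acylurea of compound 1.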